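Replacing a ring-bearing group with a ring-free one

The source may report more compounds than this note shows. Statements on the series, on what has been measured and on what is new or still open speak of the compounds shown alone.

Measured in a functional assay on HeLa cells (Homo sapiens) for inhibition, read by MTT assay, with a stated time of 48 h; on this read-out higher numbers stand for weaker inhibition and lower numbers for stronger inhibition:
- Compound 1 `CCOC(=O)C1=C(N/C=N/c2ccccn2)Nc2[nH]nc(C)c2C1c1ccc(N(C)C)cc1`: 29200 nM
- Compound 2 `CCOC(=O)C1=C(N/C=N/c2ccc(C)cc2)Nc2[nH]nc(C)c2C1c1ccc(N(C)C)cc1`: 43200 nM

For the measured compounds named here, only one other number stands beside compound 2, and the two cannot be told apart: the measured step is a 1.5-fold higher number from compound 1 to compound 2 (0.17 log units; within the scatter). Compound 3 `CCOC(=O)C1=C(N/N=C(/C(C)=O)C(=O)OCC)Nc2[nH]nc(C)c2C1c1ccc(N(C)C)cc1` is still unmeasured in this assay. Its change from compound 2 is larger: a group of 10 heavy atoms (6 carbon, 1 nitrogen, 3 oxygen; no ring) in place of a group of 9 heavy atoms (8 carbon, 1 nitrogen; one six-membered aromatic ring of carbon only), on an amine nitrogen. A group with no ring thus replaces one holding a six-membered aromatic ring of carbon only. Going by the values given here, the single measured step, a 1.5-fold higher number from compound 1 to compound 2 (0.17 log units; within the scatter), exchanged one ring-bearing group for another, so it is only a weak guide. Among the compounds with values here, no measured compound carries a ring-free group here, and the data give no direction. No shift beyond the scatter is therefore expected, though with real uncertainty. The expected step is a 1.2-fold lower number from compound 2 to compound 3 (0.09 log units; within the scatter). For compound 3 the estimated value is 35000 nM, within an expected range from 12000 nM to 100000 nM.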

Compound 3, half-maximal inhibitory concentration: > 100000 nM
Compound 3 gave a limit, no number; the forecaster's own chance of this, stated with the estimate: 15%; middle value at least 2.8-fold (0.45 log units) from the limit.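

In this assay compound 3 gives a limit of the assay, not a number: the limit of > 100000 nM in this assay, at which 1 of the 3 values shown sits.

Even so, this is the first change among these compounds to move the number beyond the scatter, with an at least 2.3-fold higher number from compound 2 to compound 3 (0.36 log units; beyond the scatter) and an at least 3.4-fold higher number from compound 1 to compound 3 (0.53 log units; beyond the scatter). Exchanging one ring-bearing group for another left the number within the scatter, whereas the ring-free group on this amine nitrogen gives weaker inhibition against both ring-bearing compounds, so this position is not indifferent to the group it carries.

On these data alone, what remains open is whether losing the ring matters most or whether the other features of the entering group do. A plain butyl chain or a saturated cyclohexyl ring in the same place would help to separate the two.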